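Amide Variation at the Cytotoxicity Limit

The source may hold more compounds than are shown below. What is called first, only, known or untested is meant among the compounds shown, and "the series" means these compounds.

Compound 1 `Cc1cccc(NC(=O)c2c(NO)cc(-c3cccs3)oc2=O)c1`: > 20000 nM in an ADME assay on Huh-7 cells (Homo sapiens) for cytotoxicity, with a stated time of 3 days (on this read-out higher numbers stand for lower toxicity in this test and lower numbers for higher toxicity in this test), a limit of the assay.
Compound 2 `COc1ccc(NC(=O)c2c(NO)cc(-c3cccs3)oc2=O)cc1`: > 20000 nM in this assay, a limit of the assay.

Compound 2 thus stands at the assay limit, and the step that the two limits leave unreadable from compound 1 to compound 2 cannot be read. Going by the values given here, the only evidence is the limit of > 20000 nM in this assay, at which 2 of the 2 values shown sit. Compound 3 `Nc1ccccc1NC(=O)c1c(NO)cc(-c2cccs2)oc1=O` differs from compound 2 by 2-aminophenyl in place of 4-methoxyphenyl on an amide-type nitrogen. Among the compounds with values here, no measured step bears readably on this change, so no move beyond the scatter is expected in this assay, and the expected step is a number no higher from compound 2 to compound 3 (the limit leaves the size open). Compound 3 is therefore estimated at 20000 nM, within 8000 nM to 50000 nM, most likely again reported only as a limit.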

Compound 3, half-maximal cytotoxic concentration: > 20000 nM
Compound 3 ended at the assay's limit; the forecaster's own chance of this, stated with the estimate: 75%; the middle value sits exactly at the limit.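

No step can be read among compound 1, compound 2 and compound 3, since each stands at the limit of this assay: the limit of > 20000 nM in this assay, at which 3 of the 3 values shown sit.

These compounds leave open how far any of the three amide substituents separates from another beyond that limit.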